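The source may hold more compounds than are shown below. What is called first, only, known or untested is meant among the compounds shown, and "the series" means these compounds.

Working notes on the amide and urea series built on the shared core. Compound 1 `COc1cc(-c2nn(-c3cccc(NC(=O)Nc4cc(C(F)(F)F)cc(C(F)(F)F)c4)c3)cc2-c2ccncc2)ccc1Cl` is the urea member; compound 2 `COc1cc(-c2nn(-c3cccc(NC(=O)c4cccc(C(F)(F)F)c4)c3)cc2-c2ccncc2)ccc1Cl` is the 3-(trifluoromethyl)phenyl amide. In a functional assay on T47D cells (Homo sapiens) for inhibition, read by sulforhodamine B assay, with a stated time of 48 h (a higher number here means a weaker inhibitor of growth, a lower number a stronger inhibitor of growth), compound 1 gives no number, only a limit, > 50000 nM. In this assay compound 2 likewise returns only a limit, > 50000 nM. Both results sit at the limit of > 50000 nM in this assay, at which 2 of the 2 values shown sit, so compound 2 stands at the ceiling of what has been read, and no ordering of compound 1 against compound 2 can be drawn from these two entries. Within the data shown here, no pair of measured compounds differs in a single place, so no step size has been established anywhere in the set.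

Compound 3 `COc1cc(-c2nn(-c3cccc(NC(=O)c4ccc(Cl)c(C(F)(F)F)c4)c3)cc2-c2ccncc2)ccc1Cl` is the next member, and it differs from compound 2 by chloro in place of hydrogen on an aromatic carbon. With nothing measured on either side of this change, the working expectation is a step of no size beyond the scatter, a step that the limit leaves unreadable from compound 2 to compound 3, rather than a shift in either direction. Compound 3 is therefore expected near 60000 nM, within a range of 20000 nM to 200000 nM, and most probably it too will come back as a limit.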

Compound 3, concentration for total growth inhibition: > 32500 nM
Compound 3: a limit, no number; the forecaster's own chance of this, stated with the estimate: 75%; the middle value lies beyond the limit too.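

In this assay compound 3 gives only a limit, > 32500 nM. Compound 2 likewise gives only a limit, > 50000 nM, so no step can be read between compound 2 and compound 3. The compounds shown leave open whether chloro in place of hydrogen shifts growth inhibition at all, and what concentration any member of the series would need for total growth inhibition.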